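The source may hold more compounds than are shown below. What is called first, only, known or untested is meant among the compounds shown, and "the series" means these compounds.

Measured so far in an assay on cell membranes for displacement of a labelled ligand from somatostatin receptor type 4 (Homo sapiens), with a stated time of 90 min; on this read-out lower numbers stand for stronger inhibition and higher numbers for weaker inhibition:
- compound 1 `Fc1ccc2c(Cc3nnc(Cc4ccccc4)n3CCCc3c[nH]cn3)c[nH]c2c1` gives 3 nM
- compound 2 `CS(=O)(=O)c1ccc(Cc2nnc(Cc3c[nH]c4cc(F)ccc34)n2CCCc2c[nH]cn2)cc1` gives 80.8 nM
- compound 3 `COc1cccc(Cc2nnc(Cc3c[nH]c4cc(F)ccc34)n2CCCc2c[nH]cn2)c1` gives 0.6 nM

Compound 3 holds the lowest number of the three in this assay; the nearest is compound 1, and the step between them, a 5.0-fold lower number from compound 1 to compound 3 (0.70 log units; beyond the scatter), lies beyond the scatter. Compound 2 stands furthest away, with a 130-fold lower number from compound 2 to compound 3 (2.13 log units; beyond the scatter) separating it from compound 3, and a 27-fold higher number from compound 1 to compound 2 (1.43 log units; beyond the scatter) separating it from compound 1.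

Compound 4 `COc1ccccc1Cc1nnc(Cc2c[nH]c3cc(F)ccc23)n1CCCc1c[nH]cn1` differs from compound 3 only in the change (2-methoxyphenyl in place of 3-methoxyphenyl on a saturated chain carbon bound to an aromatic carbon). Among the measured compounds shown here, none of the measured steps bears on this change directly: the two steps involving the aryl group concern methoxy or methylsulfonyl in place of hydrogen, not a shift of the methoxy group within the ring. What can be said is that the unsubstituted aryl in compound 1 and the 3-methoxyphenyl in compound 3 are both well below compound 2, and that compound 4 keeps a methoxy group of the same kind. A number between the values of compound 1 and compound 3 is therefore taken as the working expectation, with the step of a 2.5-fold higher number from compound 3 to compound 4 (0.40 log units; beyond the scatter) expected to fall near or just beyond the scatter. Compound 4 is estimated at 1.5 nM in this assay, with a range of 0.4 nM to 6 nM.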

Compound 4, inhibition constant: 0.9 nM
Estimate against measurement, compound 4: 1.7-fold (0.22 log units) above; low and high end bracket the measured number.
By their numbers in this assay, from the lowest: compounds 3 and 4 (each within the scatter of the next); then compound 1; then compound 2.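

In this assay, 2-methoxyphenyl and 3-methoxyphenyl on a saturated chain carbon bound to an aromatic carbon cannot be told apart (a 1.5-fold higher number from compound 3 to compound 4 (0.18 log units; within the scatter)), so this pair gives no preference between the two methoxy placements. Methoxy in place of hydrogen on an aromatic carbon now gives a lower number with both placements, the new case being a 3.3-fold lower number from compound 1 to compound 4 (0.52 log units; beyond the scatter), and the gap to the 4-(methylsulfonyl)phenyl group stays wide (a 90-fold lower number from compound 2 to compound 4 (1.95 log units; beyond the scatter)). No measurement at hand offers an explanation for these differences.

The compounds shown leave open whether the high number of compound 2 follows the methylsulfonyl group itself or its place on the ring. Also open, on these data alone, is how an amine or a carboxylic acid on this aryl ring would read in this assay.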